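Removing the Fluoromethyl Group from a Difluorinated Alcohol

This account rests on a few compounds, and the source may have more. Where it says the series, first, only, none or still open, it means among the compounds named here.

As far as these compounds go, this account concerns two alcohols measured in a physicochemical assay for lipophilicity, read by NMR (a higher number here means a more lipophilic compound, a lower number a more polar compound), and a third whose value is still open. Compound 1, `OCCCC(F)CF`, gives 0.11 in this assay, which is the lower of the two numbers found so far. The other is compound 2, `FCC(F)COc1ccc2[nH]ccc2c1`, which gives 2.3 in this assay, a value that lies above compound 1 by a margin well beyond the usual scatter. Within the data shown here, no pair of compounds that differ in a single place has been measured yet, so the step to the third compound has to be judged from its structure alone.

Compound 3 is `OCCCCF`. It differs from compound 1 by hydrogen in place of fluoromethyl on a saturated chain carbon bound to a fluorine atom and a saturated chain carbon. The fragment that leaves carries two heavy atoms and no donor or acceptor, and in this assay such a loss is expected to move the number downward by an amount that clearly exceeds the scatter, though not by a large margin. The step that this estimate implies is a number 0.46 log units lower from compound 1 to compound 3 (beyond the scatter), expected downward. Compound 3 is accordingly estimated at -0.35, with a likely range from -0.9 to 0.2.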

Compound 3, partition coefficient: 0.09
Compound 3: middle estimate off by 0.44 log units, on the low side; measured number inside the range.
By their numbers in this assay, from the lowest: compounds 3 and 1 (each within the scatter of the next); then compound 2.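

In this assay, hydrogen in place of fluoromethyl on a saturated chain carbon bound to a fluorine atom and a saturated chain carbon gives a number 0.02 log units lower from compound 1 to compound 3 (within the scatter), so the two compounds cannot be told apart in this read-out. Among these compounds, this is the first pair in the account that differs in one place, and it shows that, on this alcohol chain, a fragment of 2 heavy atoms with 0 hydrogen-bond donors and 0 hydrogen-bond acceptors can leave without a step beyond the scatter. No measurement offered here bears on the reason for this result.

As far as these compounds go, whether the same exchange gives a step of this size on a longer chain, or on a chain that ends in an amine or a carboxylic acid in place of the alcohol, stays open. Also open, from the compounds shown here alone, are whether it would do so on the core of compound 2, and whether a methyl or trifluoromethyl group at this place would stay within the scatter of compound 1.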